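Working notes: hydroxy to isopropyl on the pendant phenyl

A few compounds are considered here, and "the series" means these few. Any claim that something is new, unique, unknown or untested is made for them only; others in the source may bear on it.

In an assay for binding affinity to dual specificity mitogen-activated protein kinase kinase 4 (Homo sapiens), read by KINOMEscan, tested at 100 nM (a higher number here means a weaker effect of the compound at the concentration tested, a lower number a stronger effect), compound 2 `CCCS(=O)(=O)Nc1ccc(F)c(C(=O)c2n[nH]c3ncc(-c4ccc(O)cc4)cc23)c1F` gives 0.75%. Among the measured compounds shown here, the only other measured compound, compound 1 `CCCS(=O)(=O)Nc1ccc(F)c(C(=O)c2n[nH]c3ncc(-c4ccccc4Cl)cc23)c1F`, gives 9.3% in this assay, and the step of a number 8.6 percentage points lower from compound 1 to compound 2 (within the scatter) lies within the scatter, so the two compounds cannot be ranked against each other on these numbers; both sit at the strong end of the read-out. Compound 3 `CCCS(=O)(=O)Nc1ccc(F)c(C(=O)c2n[nH]c3ncc(-c4ccc(C(C)C)cc4)cc23)c1F` differs from compound 2 by isopropyl in place of hydroxy on an aromatic carbon. For the measured compounds named here, no measured step touches this position in this way: the single step available, from compound 1 to compound 2, exchanges a 2-chlorophenyl for a 4-hydroxyphenyl and stays within the scatter, so it gives no sign that this part of the molecule moves the read-out strongly in either direction. The expected step of a number 4.3 percentage points higher from compound 2 to compound 3 (within the scatter) in this assay is therefore none beyond the scatter, with the estimate kept near the numbers of the two measured compounds. Compound 3 is estimated at 5% in this assay, with a range from 0.3% to 25%.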

Compound 3, a percentage reported as activity, at one concentration (the size of the read-out at that concentration, not a potency): 17%
The estimate for compound 3 lay 12 percentage points below the measured number; the range from low to high includes it.
By their numbers in this assay, from the lowest: compounds 2, 1 and 3 (each within the scatter of the next, the first and the last beyond it).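

In this assay, among the compounds shown here, the change from hydroxy to isopropyl gives the first step to clear the scatter, a number 16.3 percentage points higher from compound 2 to compound 3 (beyond the scatter), a modest step that shows a group at this place on the six-membered aromatic ring can move the read-out, which the earlier pair could not show. The change replaces one oxygen, carrying a hydrogen-bond donor and acceptor, with three carbons carrying neither, and the effect at the concentration tested weakens only modestly, while the comparison with the 2-chlorophenyl compound does not separate the two, with a number 7.7 percentage points higher from compound 1 to compound 3 (within the scatter). No supporting measurement bears on why the read-out moves with this change.

The compounds shown do not tell whether the step follows the loss of the hydroxy or the arrival of the three carbons, and a methoxy, an amine or a methyl at the same place would help to separate those two readings. As far as these compounds go, how far the read-out would move with a longer chain or a carboxylic acid at this place also remains open.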